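Aryl groups in place of a cyanoethyl chain on the shared core

The compounds below may be only part of what the source reports. "The series", "measured", "known", "first", "only" and "open" are said of these compounds alone.

Measured compounds in a functional assay on MGC-803 cells (Homo sapiens) for inhibition, read by MTT assay, with a stated time of 72 h; on this read-out lower numbers stand for stronger inhibition and higher numbers for weaker inhibition:
compound 1 `C#CCSc1nc(NCCC#N)c2ccncc2n1`: > 80000 nM
compound 2 `C#CCSc1nc(Nc2ccccc2)c2ccncc2n1`: 16200 nM
compound 3 `C#CCSc1nc(Nc2ccc(C)cc2)c2ccncc2n1`: 8090 nM

Compound 1 stands at the limit of > 80000 nM in this assay, at which 1 of the 3 values shown sits, so its value is a limit rather than a number. The measured steps that bear on the change are an at least 4.9-fold lower number from compound 1 to compound 2 (0.69 log units; beyond the scatter) and an at least 9.8-fold lower number from compound 1 to compound 3 (0.99 log units; beyond the scatter), both replacing 2-cyanoethyl with an aromatic ring, while a 2.0-fold lower number from compound 2 to compound 3 (0.30 log units; within the scatter) shows that a methyl on that ring adds nothing beyond the scatter.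

Compound 4 `C#CCSc1nc(Nc2cccc(Cl)c2)c2ccncc2n1` differs from compound 1 by 3-chlorophenyl in place of 2-cyanoethyl on a nitrogen on an aromatic ring. Since another aromatic ring enters here, a step like those seen is expected: an at least 7.2-fold lower number from compound 1 to compound 4 (0.86 log units; beyond the scatter). Compound 4 is therefore estimated at 11000 nM, likely between 3500 nM and 35000 nM.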

Compound 4, half-maximal inhibitory concentration: 2190 nM
Compound 4: middle estimate off by 5.0-fold (0.70 log units), on the high side; the measured number lies below the stated range.
By their numbers in this assay, from the lowest: compound 4; then compounds 3 and 2 (each within the scatter of the next). At a limit, above all of these: compound 1.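

Chloro on the ring does what the methyl of compound 3 did not: it gives a 7.4-fold lower number from compound 2 to compound 4 (0.87 log units; beyond the scatter), and the 3-chlorophenyl group also outdoes 4-methylphenyl, with a 3.7-fold lower number from compound 3 to compound 4 (0.57 log units; beyond the scatter). So the choice of aryl group matters here, not just the presence of an aromatic ring. Against the original chain, the change gives an at least 36-fold lower number from compound 1 to compound 4 (1.56 log units; beyond the scatter), a large step read against a limit rather than a number: the limit of > 80000 nM in this assay, at which 1 of the 4 values shown sits.

On these data alone, compound 3 and compound 4 differ in both the group and where it sits, so which of these counts stays open. As far as these compounds go, whether an amine or a carboxylic acid on that ring would serve as well is also open.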